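Amide aryl variation on the shared bis-indole nitrile core

This account rests on a few compounds, and the source may have more. Where it says the series, first, only, none or still open, it means among the compounds named here.

Three amides on the shared core have numbers in a functional assay on BGC-823 cells (Homo sapiens) for cytotoxicity, read by MTT assay, with a stated time of 72 h; a higher number here means a weaker inhibitor, a lower number a stronger inhibitor. Compound 1 `CCc1ccc(C(=O)NC[C@H]2c3[nH]c4ccccc4c3C[C@H]3[C@H]4c5[nH]c6ccccc6c5C[C@@H]([C@H](C#N)N23)N4C)cc1` gives 660 nM. Among the measured compounds shown here, compound 2 `CN1[C@@H]2c3[nH]c4ccccc4c3C[C@H]1[C@H](C#N)N1[C@@H](CNC(=O)c3cc4ccccc4[nH]3)c3[nH]c4ccccc4c3C[C@@H]21` gives 1690 nM, with a 2.6-fold higher number from compound 1 to compound 2 (0.41 log units; beyond the scatter) the only step beyond the scatter. Compound 3 `CN1[C@@H]2c3[nH]c4ccccc4c3C[C@H]1[C@H](C#N)N1[C@@H](CNC(=O)/C=C/c3cccc(C(F)(F)F)c3)c3[nH]c4ccccc4c3C[C@@H]21` gives 910 nM; it is the second highest of the three numbers, yet a 1.4-fold higher number from compound 1 to compound 3 (0.14 log units; within the scatter) and a 1.9-fold lower number from compound 2 to compound 3 (0.27 log units; within the scatter) both fall within the scatter, so compound 3 is not separated from either neighbour.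

Compound 4 `COc1ccc(/C=C/C(=O)NC[C@H]2c3[nH]c4ccccc4c3C[C@H]3[C@H]4c5[nH]c6ccccc6c5C[C@@H]([C@H](C#N)N23)N4C)cc1` differs from compound 3 by 4-methoxyphenyl in place of 3-(trifluoromethyl)phenyl on a double-bonded chain carbon bound to a double-bonded chain carbon. For the measured compounds named here, no measured step alters only the aryl on the ethenyl; the nearest comparisons swap the whole amide substituent, and those swaps, a 1.4-fold higher number from compound 1 to compound 3 (0.14 log units; within the scatter) and a 1.9-fold lower number from compound 2 to compound 3 (0.27 log units; within the scatter), stayed inside the scatter. On that basis the expected step of a 1.0-fold lower number from compound 3 to compound 4 (0.00 log units; within the scatter) in this assay is small, with no direction established beyond the scatter. Compound 4 is therefore estimated at 900 nM in this assay, within a range of 400 nM to 2000 nM.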

Compound 4, half-maximal inhibitory concentration: 5450 nM
For compound 4 the middle estimate is 6.1-fold (0.78 log units) below the measured one, and the stated range ends below it.
By their numbers in this assay, from the lowest: compounds 1, 3 and 2 (each within the scatter of the next, the first and the last beyond it); then compound 4.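

In this assay, among the compounds shown here, the aryl on the ethenyl is not a silent position: 4-methoxyphenyl in place of 3-(trifluoromethyl)phenyl gives a 6.0-fold higher number from compound 3 to compound 4 (0.78 log units; beyond the scatter) as the only step that alters this aryl alone, and it is wider than any step among compounds 1, 2 and 3. The 2-(4-methoxyphenyl)ethenyl amide also stands apart from the other two amides, with a 3.2-fold higher number from compound 2 to compound 4 (0.51 log units; beyond the scatter) and an 8.3-fold higher number from compound 1 to compound 4 (0.92 log units; beyond the scatter) as its steps, so compound 4 is the weakest of the four. No measurement here accounts for this step.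

The change from 3-(trifluoromethyl)phenyl to 4-methoxyphenyl alters the group and its ring position together, and the compounds shown do not separate the two. Also open, going by these compounds, is how 3-methoxyphenyl, 4-(trifluoromethyl)phenyl or an aminophenyl would read on the same ethenyl.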